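The compounds below may be only part of what the source reports. "The series", "measured", "known", "first", "only" and "open" are said of these compounds alone.

Measured compounds in a functional assay on MCF7 cells (Homo sapiens) for inhibition, read by MTT assay, with a stated time of 48 h; a higher number here means a weaker inhibitor, a lower number a stronger inhibitor:
Compound 1 `Cc1cccc2c1OCN(c1ccc3oc(-c4ccccc4)cc(=O)c3c1)C2` gives 14300 nM
Compound 2 `O=c1cc(-c2ccccc2)oc2ccc(N3COc4ccccc4C3)cc12` gives 27500 nM
Compound 3 `Cc1cccc2c1OCN(c1ccc3c(=O)cc(-c4ccccc4)oc3c1)C2` gives 14900 nM

Compound 1 and compound 2 share a core and differ in one place: hydrogen in place of methyl on an aromatic carbon. This change produced a 1.9-fold higher number from compound 1 to compound 2 (0.28 log units; within the scatter), a step that stays inside the usual scatter of repeated measurements, so the two numbers cannot be told apart with confidence.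

Compound 3 is built from the same atoms as compound 1, joined differently; the difference between the two cores is not broken down here. In this assay compound 3 gives 14900 nM, and this lies close to the number for compound 1, well inside the scatter.

Compound 4 `O=c1cc(-c2ccccc2)oc2cc(N3COc4ccccc4C3)ccc12` has not yet been measured. It differs from compound 3 by hydrogen in place of methyl on an aromatic carbon, the same change, at a place described in the same terms, as that which takes compound 1 to compound 2. On the strength of the measured step of a 1.9-fold higher number from compound 1 to compound 2 (0.28 log units; within the scatter), the step from compound 3 to compound 4 is expected to be of the same small size, a 1.9-fold higher number from compound 3 to compound 4 (0.27 log units; within the scatter), again within the scatter. Compound 4 is therefore estimated to give 28000 nM in this assay. The range expected for compound 4 runs from 14000 nM to 56000 nM; it is kept wide, since a single measured example of the change is all that the data offer.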

Compound 4, half-maximal inhibitory concentration: "not active" (no number reported)
The entry for compound 4 holds no number; there is nothing to compare the estimate with.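

In this assay, within the data shown here, compound 4 is recorded as "not active" with no number, so no step from compound 3 to compound 4 can be read. Nothing in the data shown bears on this entry. The compounds shown leave open how far compound 4 stands from compound 3, and whether hydrogen in place of methyl acts alike on the two cores.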